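Adding bromo to the core of compound 1

The source may hold more compounds than are shown below. What is called first, only, known or untested is meant among the compounds shown, and "the series" means these compounds.

Measured in a functional assay on HT-29 cells (Homo sapiens); on this read-out higher numbers stand for weaker inhibition of growth and lower numbers for stronger inhibition of growth:
Compound 1 `O=S(=O)(/C=C/c1ccc(Cl)c(Cl)c1)Cc1ccc(Nc2ncnc3ccccc23)cc1`: 11000 nM
Compound 2 `O=S(=O)(/C=C/c1ccc(Cl)cc1)Cc1ccc(Nc2ncnc3ccccc23)cc1`: 73000 nM
Compound 3 `O=S(=O)(/C=C/c1ccc(O)cc1)Cc1ccc(Nc2ncnc3ccccc23)cc1`: 2000 nM

Compound 1 holds the middle place, with the second highest of the three numbers. Compound 4 `O=S(=O)(/C=C/c1ccc(Cl)c(Cl)c1)Cc1ccc(Nc2ncnc3ccc(Br)cc23)cc1` keeps all of compound 1 except for one change on the core: bromo in place of hydrogen on an aromatic carbon. Among the measured compounds shown here, no measured step touches the core, so the evidence is only indirect. The closest match is a 6.6-fold higher number from compound 1 to compound 2 (0.82 log units; beyond the scatter), a modest step with hydrogen in place of chloro on an aromatic carbon. Read in reverse, that swap adds a chloro and gives a lower number. The hydroxy steps, a 5.5-fold lower number from compound 1 to compound 3 (0.74 log units; beyond the scatter) and a 37-fold lower number from compound 2 to compound 3 (1.56 log units; beyond the scatter), show that a change at one place can matter greatly in this assay, but they involve a different kind of group. A modest step towards a lower number is therefore expected, though its direction is uncertain. The estimated step is a 2.2-fold lower number from compound 1 to compound 4 (0.34 log units; beyond the scatter). For compound 4 the estimated value is 5000 nM, with an expected range from 1500 nM to 20000 nM.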

Compound 4, concentration for 50% growth inhibition: 27000 nM
Beside the measured number, compound 4's estimate is 5.4-fold (0.73 log units) below it; measured number above the stated range.
By their numbers in this assay, from the lowest: compound 3; then compound 1; then compound 4; then compound 2.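

In this assay, a 2.5-fold higher number from compound 1 to compound 4 (0.39 log units; beyond the scatter) gives the first measured view of a change on the shared core, and it shows that this aromatic carbon does not tolerate bromo without a cost: growth inhibition becomes weaker. It also shows that adding a halogen does not lower the number everywhere, as the chloro that separates compound 2 from compound 1 goes with a lower number, in a 6.6-fold higher number from compound 1 to compound 2 (0.82 log units; beyond the scatter), while bromo on the core goes the other way. No measurement here explains this shift.

From the compounds shown here alone, whether the loss belongs to bromo itself or would follow any group at this carbon stays open, and an amine or a methoxy group there would help tell these apart. Also open, going by these compounds, is whether bromo would raise the number to a similar extent on the 4-hydroxyphenyl compound 3.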